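This account rests on a few compounds, and the source may have more. Where it says the series, first, only, none or still open, it means among the compounds named here.

Of the compounds shown here, three that share one core have been tested in an in vitro assay on HEK385-7 cells for displacement of a labelled ligand from prostaglandin D2 receptor 2 (Homo sapiens); on this read-out lower numbers stand for stronger inhibition and higher numbers for weaker inhibition. Compound 1 `O=C(O)Cc1sc(COc2ccc(Cl)cc2)nc1-c1ccc(Cl)cc1` gives 32 nM. Compound 2 `O=C(O)Cc1sc(C(c2ccc(F)cc2)c2ccc(F)cc2)nc1-c1ccco1` gives 18 nM, the lowest of the three numbers. Compound 3 `O=C(O)Cc1sc(NCc2ccccc2)nc1-c1ccc(Cl)cc1` gives 440 nM. The numbers for compound 2 and compound 1 sit within the scatter of each other, so no order between the two can be claimed; compound 3, by contrast, sits beyond the scatter from compound 2, with a plainly higher number.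

Compound 4 `CN(C)c1cc(-c2nc(C(c3ccc(F)cc3)c3ccc(F)cc3)sc2CC(=O)O)ccn1` differs from compound 2 in a single place: 2-(dimethylamino)pyridin-4-yl in place of furan-2-yl on an aromatic carbon. Going by the values given here, no measured pair shows the effect of such a swap, so its size cannot be read off from the data. Compound 1 and compound 2 carry different groups at this same place and still sit close to each other, which gives a modest hint that the place tolerates variation, though two examples prove little. The expected step of a 1.7-fold higher number from compound 2 to compound 4 (0.22 log units; within the scatter) is therefore small, in neither direction beyond the scatter, with a wide range of uncertainty. Compound 4 is expected to give about 30 nM, somewhere between 8 nM and 120 nM.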

Compound 4, half-maximal inhibitory concentration: 380 nM
Compound 4: middle estimate off by 13-fold (1.10 log units), on the low side; measured number above the stated range.
By their numbers in this assay, from the lowest: compounds 2 and 1 (each within the scatter of the next); then compounds 4 and 3 (each within the scatter of the next).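

In this assay, 2-(dimethylamino)pyridin-4-yl in place of furan-2-yl on this aromatic carbon brings a 21-fold higher number from compound 2 to compound 4 (1.32 log units; beyond the scatter), the first one-place change measured in this set. The position therefore does not accept every aromatic group alike, and the earlier hint of tolerance, drawn from compounds that differ in more than one place, does not hold for this swap. No measurement on hand explains the higher number.

From the compounds shown here alone, the change brings in a six-membered ring, a ring nitrogen and a dimethylamino group all at once, so it remains open which of these goes with the higher number. Compounds with plain pyridin-4-yl or plain phenyl at this place, set against compound 2, could begin to separate those parts.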